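This account rests on a few compounds, and the source may have more. Where it says the series, first, only, none or still open, it means among the compounds named here.

In a functional assay on M21 cells (Homo sapiens) for antiproliferative activity, read by sulforhodamine B assay, with a stated time of 48 h (on this read-out higher numbers stand for weaker inhibition and lower numbers for stronger inhibition), compound 1 `Cc1ccc(NS(=O)(=O)c2ccc(N3CCNC3=O)cc2)cc1C` gives 94 nM and compound 2 `Cc1cc(C)cc(NS(=O)(=O)c2ccc(N3CCNC3=O)cc2)c1` gives 63 nM while compound 3 `Cc1ccc(C)c(NS(=O)(=O)c2ccc(N3CCNC3=O)cc2)c1` gives 27 nM as the lowest of the three numbers. Compound 4 `O=C1NCCN1c1ccc(S(=O)(=O)Nc2cccc(Cl)c2)cc1` carries 3-chlorophenyl in place of 2,5-dimethylphenyl on a sulfonamide nitrogen. The steps bearing on this change are a 3.5-fold lower number from compound 1 to compound 3 (0.54 log units; beyond the scatter) and a 2.3-fold lower number from compound 2 to compound 3 (0.37 log units; beyond the scatter) (both modest). For the measured compounds named here, compound 1 and compound 2 lack 2,5-dimethylphenyl, as does compound 4, and no measured compound carries 3-chlorophenyl. A modest step to a higher number in this assay is therefore expected (estimated as a 3.0-fold higher number from compound 3 to compound 4 (0.47 log units; beyond the scatter)). For compound 4 the estimated value is 80 nM (expected range 30 nM to 220 nM).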

Compound 4, half-maximal inhibitory concentration: 25 nM
Estimate against measurement, compound 4: 3.2-fold (0.51 log units) above; measured number below the stated range.
By their numbers in this assay, from the lowest: compounds 4 and 3 (each within the scatter of the next); then compounds 2 and 1 (each within the scatter of the next).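

In this assay, 3-chlorophenyl on a sulfonamide nitrogen reads level with 2,5-dimethylphenyl, with a 1.1-fold lower number from compound 3 to compound 4 (0.03 log units; within the scatter), so the low end of this small set does not depend on two methyl groups on this phenyl. Against the other two dimethylphenyl groups, the same exchange gives a 2.5-fold lower number from compound 2 to compound 4 (0.40 log units; beyond the scatter) and a 3.8-fold lower number from compound 1 to compound 4 (0.58 log units; beyond the scatter), placing 3-chlorophenyl with 2,5-dimethylphenyl ahead of both. On these data alone, how a methoxy group, an amine or a carboxylic acid would read in place of the chlorine remains open. Nothing available explains why these groups differ or match.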